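Sulfonyl substituent variation on the shared core

The source may report more compounds than this note shows. Statements on the series, on what has been measured and on what is new or still open speak of the compounds shown alone.

Measured compounds:
compound 1, `COc1ccc(-c2cc(=O)c3c(OC)cc(OC)cc3n2C)cc1`: in a functional assay on HepG2 cells (Homo sapiens) for antiproliferative activity, with a stated time of 72 h (a lower number here means that less compound is needed, a higher number that more compound is needed for the effect), compound 1 gives "not determined" (no result reported).
compound 2, `COc1ccc(-c2cc(=O)c3c(OC)cc(OC)cc3n2S(=O)(=O)c2cc(F)c(F)c(F)c2)cc1`: in this assay compound 2 gives > 65500 nM, which is a limit of the assay and not a number.
compound 3, `COc1ccc(-c2cc(=O)c3c(OC)cc(OC)cc3n2S(=O)(=O)c2ccc(C)cc2)cc1`: in this assay compound 3 gives > 44800 nM, again only a limit.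

Compound 3 therefore stands at a limit; of the other two entries one is also a limit and one carries no number, so compound 3 cannot be ranked against any neighbour. For the measured compounds named here, the single step among the measured compounds, a step that the two limits leave unreadable from compound 2 to compound 3, runs between two limits and its size is unreadable; what remains is the limit of > 44800 nM in this assay, at which 1 of the 3 values shown sits, and (the limit of > 65500 nM in this assay, at which 1 of the 3 values shown sits).

The change leading to compound 4, `COc1ccc(-c2cc(=O)c3c(OC)cc(OC)cc3n2S(=O)(=O)Cc2ccccc2)cc1`, is benzyl in place of 4-methylphenyl on a sulfonyl sulfur. Going by the values given here, no measured step bears on this change directly, and the one step in the set gives no readable size. With both sulfonyl variants so far sitting at limits, no step beyond the scatter is expected for this assay. Compound 4 is accordingly expected to sit at about 50000 nM, within 15000 nM to 150000 nM. The expected step that the limit leaves unreadable from compound 3 to compound 4 is thus estimated as none beyond the scatter, most likely reported again as a limit.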

Compound 4, half-maximal effective concentration: > 34400 nM
Compound 4: only a limit was reported; the forecaster's own chance of this, stated with the estimate: 75%; the middle value does not contradict the limit.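

In this assay compound 4 gives > 34400 nM, again a limit of the assay and not a number. For the compounds shown here, compound 2, compound 3 and compound 4 all stand at limits, so no step among them can be read. The compounds shown leave open how these sulfonyl variants rank against one another and whether any of them has a numerical value in this assay.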